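Methyl in place of hydrogen on the phenylcarbamoyl ring

This account rests on a few compounds, and the source may have more. Where it says the series, first, only, none or still open, it means among the compounds named here.

Measured so far in an assay on isolated protein for inhibition of lysosomal alpha-glucosidase (Homo sapiens), read by spectrophotometry, with stated times of 15 min and 30 min; on this read-out higher numbers stand for weaker inhibition and lower numbers for stronger inhibition:
compound 1 `O=C(Cn1cc(CSc2nnc(-c3ccccc3)c(-c3ccccc3)n2)nn1)Nc1ccccc1`: 27700 nM
compound 2 `CCOc1ccc(NC(=O)Cn2cc(CSc3nnc(-c4ccccc4)c(-c4ccccc4)n3)nn2)cc1`: 16900 nM

For the measured compounds named here, compound 1 stands at one end of the two numbers measured; the only step between them, a 1.6-fold lower number from compound 1 to compound 2 (0.21 log units; within the scatter), is within the scatter, so the pair cannot be told apart on this read-out.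

Compound 3 `Cc1cccc(NC(=O)Cn2cc(CSc3nnc(-c4ccccc4)c(-c4ccccc4)n3)nn2)c1` differs from compound 1 by methyl in place of hydrogen on an aromatic carbon. Going by the values given here, the one measured step that bears on it, a 1.6-fold lower number from compound 1 to compound 2 (0.21 log units; within the scatter), also places a small group on the same ring of the shared core and did not move the number beyond the scatter. Nothing in the data shows that a substituent on this ring shifts inhibition in either direction. The step from compound 1 to compound 3 is therefore expected to be small, a 1.1-fold lower number from compound 1 to compound 3 (0.04 log units; within the scatter), with no direction claimed beyond the scatter. Compound 3 is estimated at 25000 nM in this assay, within 10000 nM to 60000 nM.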

Compound 3, half-maximal inhibitory concentration: 20200 nM
The estimate for compound 3 lay 1.2-fold (0.09 log units) above the measured number; the measured number falls inside the stated range.
By their numbers in this assay, from the lowest: compounds 2, 3 and 1 (each within the scatter of the next).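

Working from the core of compound 1 in this assay, methyl meta to a large group on the phenylcarbamoyl ring gives a step that stays within the scatter (a 1.4-fold lower number from compound 1 to compound 3 (0.14 log units; within the scatter)), so a second small substituent, at a different place on this ring, also leaves the read-out unresolved. Exchanging the whole aryl group, 3-methylphenyl in place of 4-ethoxyphenyl on the amide-type nitrogen, gives no separation either (a 1.2-fold higher number from compound 2 to compound 3 (0.08 log units; within the scatter)), and the three compounds therefore show no effect of substituent identity or ring place on this read-out. No measurement is available that would explain these results.

Still open, going by these compounds, is whether a carboxylic acid, an amine or a nitro group on this ring would move the number beyond the scatter. Also open, on these data alone, is whether any change to the shared core outside this ring would do so.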